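Swapping Piperidine for Piperazine on a Shared Core

A few compounds are considered here, and "the series" means these few. Any claim that something is new, unique, unknown or untested is made for them only; others in the source may bear on it.

Of the compounds shown here, three built on one shared core have been tested in a functional assay on the whole organism (strain Wistar) for inhibition, with Rattus norvegicus as the target, read by paw edema, with stated times of 60 min and 24 h, at a dose of 100 mg/kg by the oral route; a higher number here means more inhibition at the dose given (going by the name of the read-out), a lower number less inhibition. Compound 1 `CCCNC(=O)CC1CCc2cc(OC)c(OC)cc21` gives 26.7%. Compound 2 `CCCCNC(=O)CC1CCc2cc(OC)c(OC)cc21` gives 36.7%, and compound 3 `COc1cc2c(cc1OC)C(CC(=O)N1CCCCC1)CC2` gives 40%. Compound 3 therefore shows the highest of the three numbers, yet its lead over compound 2 lies within the scatter, so those two cannot be ranked against each other; only its distance from compound 1 is clear, with a number 13.3 percentage points higher from compound 1 to compound 3 (beyond the scatter). The remaining steps were a number 10 percentage points higher from compound 1 to compound 2 (within the scatter) and a number 3.3 percentage points higher from compound 2 to compound 3 (within the scatter).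

Compound 4 `COc1cc2c(cc1OC)C(CC(=O)N1CCNCC1)CC2` differs from compound 3 in a single place: piperazin-1-yl in place of piperidin-1-yl on a carbonyl carbon. The measured steps that also change the group on the carbonyl carbon are those from compound 1 and from compound 2 to compound 3, and both replaced an open chain with a ring. For the measured compounds named here, neither exchanged one ring for another, and no measured pair introduces a hydrogen-bond donor at this position, so the data offer no direct guide. Since compound 3 and compound 2 sit close together, the change is expected to give a number 7 percentage points lower from compound 3 to compound 4 (within the scatter), a step that stays within the scatter. Compound 4 is thus estimated at 33%, with a likely range from 15% to 50%.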

Compound 4, a percentage reported as inhibition, in the whole organism at one dose (the size of the read-out at that dose, not a potency): 65%
The estimate for compound 4 lay 32 percentage points below the measured number, and the stated range ends below it.
By their numbers in this assay, from the lowest: compounds 1, 2 and 3 (each within the scatter of the next, the first and the last beyond it); then compound 4.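

For the compounds shown here, the group on this carbonyl carbon matters even when ring size and heavy-atom count stay the same: in this assay, piperazin-1-yl in place of piperidin-1-yl gives a number 25 percentage points higher from compound 3 to compound 4 (beyond the scatter) and so separates two rings that differ only in one ring atom, whereas the earlier steps at this place only replaced open chains with a ring. Piperazin-1-yl also stands clear of both open chains, with a number 28.3 percentage points higher from compound 2 to compound 4 (beyond the scatter) and a number 38.3 percentage points higher from compound 1 to compound 4 (beyond the scatter) in the same assay, which puts compound 4 highest of the four, although compound 3 could not be separated from compound 2. The entering ring has a second hetero atom and counts 1 hydrogen-bond donor and 1 hydrogen-bond acceptor where the leaving ring counts 0 of each, but no measurement here links either difference to the higher number.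

The compounds shown cannot tell whether the second ring nitrogen or the hydrogen on it goes with this gain; a morpholine ring or a methylpiperazine at the same carbonyl carbon would begin to separate the two. On these data alone, each figure also comes from a single dose, so how the compounds compare at other doses remains open.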